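Trifluoromethylphenyl amide in a paw edema series

The compounds below may be only part of what the source reports. "The series", "measured", "known", "first", "only" and "open" are said of these compounds alone.

Compound 1, `CNC(=O)c1nc(-c2cc(OC)c(OC)c(OC)c2)n(-c2ccc(OC)cc2)n1`, gives 74% in a functional assay on the whole organism for inhibition, with Rattus norvegicus as the target, read by paw edema, with stated times of 30 min and 3 h, at a dose of 0.28 mmol/kg by the oral route; a higher number here means more inhibition at the dose given (going by the name of the read-out), a lower number less inhibition.
Compound 2, `COc1ccc(NC(=O)c2nc(-c3cc(OC)c(OC)c(OC)c3)n(-c3ccc(OC)cc3)n2)cc1`, gives 67% in this assay.
Compound 3, `COc1ccc(-n2nc(C(=O)Nc3ccccc3C)nc2-c2cc(OC)c(OC)c(OC)c2)cc1`, gives 50% in this assay.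

Compound 3 stands lowest of the three: the step of a number 17 percentage points lower from compound 2 to compound 3 (beyond the scatter) and the step of a number 24 percentage points lower from compound 1 to compound 3 (beyond the scatter) both place it below the others, while the step of a number 7 percentage points lower from compound 1 to compound 2 (within the scatter) separates the upper two only slightly. Compound 4, `COc1ccc(-n2nc(C(=O)Nc3ccc(C(F)(F)F)cc3)nc2-c2cc(OC)c(OC)c(OC)c2)cc1`, differs from compound 3 in one place: 4-(trifluoromethyl)phenyl in place of 2-methylphenyl on an amide-type nitrogen. The step that bears on this change is the aryl-for-aryl exchange on the amide nitrogen, a number 17 percentage points lower from compound 2 to compound 3 (beyond the scatter), which was modest. A modest recovery toward the value of compound 2 is therefore expected for compound 4, as a number 10 percentage points higher from compound 3 to compound 4 (within the scatter). Compound 4 is estimated at 60%, within a range from 45% to 75%.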

Compound 4, a percentage reported as inhibition, in the whole organism at one dose (the size of the read-out at that dose, not a potency): 65%
Compound 4: middle estimate off by 5 percentage points, on the low side; low and high end bracket the measured number.
By their numbers in this assay, from the lowest: compound 3; then compounds 4, 2 and 1 (each within the scatter of the next).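

In this assay the kind of aryl group on the amide-type nitrogen matters: 4-(trifluoromethyl)phenyl in place of 2-methylphenyl gives a number 15 percentage points higher from compound 3 to compound 4 (beyond the scatter) and so the low number of compound 3 is not shared by every aryl amide here. Trifluoromethyl in place of methoxy on an aromatic carbon gives a number 2 percentage points lower from compound 2 to compound 4 (within the scatter) while 4-(trifluoromethyl)phenyl in place of methyl gives a number 9 percentage points lower from compound 1 to compound 4 (within the scatter) so neither exchange separates these compounds.

Open, from the compounds shown here alone, is whether the low number of compound 3 goes with the methyl group itself or with its place on the ring, and how 4-methylphenyl or an aryl group carrying an amine would read. Nothing shown here gives a reason for these differences.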